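The source may report more compounds than this note shows. Statements on the series, on what has been measured and on what is new or still open speak of the compounds shown alone.

Measured compounds in the series:

Compound 1, `CC(C)N(Cc1cccc(OCCCCCC(=O)O)c1)C(=O)c1ccccc1`: in an ADME assay on Raji cells (Homo sapiens) for cytotoxicity, read by CellTiter-Glo and resazurin assay, with a stated time of 72 h (on this read-out higher numbers stand for an effect only at larger amounts of compound and lower numbers for an effect already at smaller amounts), compound 1 reaches only the limit > 26000 nM.
Compound 2, `CC(C)N(Cc1cccc(OCCCCCC(=O)O)c1)C(=O)c1ccc(-c2cccc(Cl)c2)cc1`: in this assay compound 2 reaches only the limit > 21900 nM.
Compound 3, `CCOC(=O)CCCCCOc1cccc(CN(C(=O)c2ccccc2)C(C)C)c1`: in this assay compound 3 reaches only the limit > 26000 nM.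

Compound 3 therefore stands where every measured value stands, at a limit and not at a number; the values sit at the limit of > 26000 nM in this assay, at which 2 of the 3 values shown sit, and at the limit of > 21900 nM in this assay, at which 1 of the 3 values shown sits. The steps a step that the two limits leave unreadable from compound 1 to compound 2 and a step that the two limits leave unreadable from compound 1 to compound 3 are both unreadable, since each runs from one limit to another.

Compound 4, `CCOC(=O)CCCCCOc1cccc(CN(C(=O)c2ccc(-c3cccc(OCC(C)C)c3)cc2)C(C)C)c1`, is not yet measured. The change from compound 3 is 3-(isobutoxy)phenyl in place of hydrogen on an aromatic carbon. Among the measured compounds shown here, the only measured step of the same kind, an aryl group in place of hydrogen on an aromatic carbon, is a step that the two limits leave unreadable from compound 1 to compound 2, and it gives no readable size. For the measured compounds named here, nothing among the measured values points to a step in either direction in this assay beyond the scatter; a further limit is the most likely outcome.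

The expected step that the limit leaves unreadable from compound 3 to compound 4 is essentially none. Compound 4 is estimated at 30000 nM, within 8000 nM to 100000 nM.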

Compound 4, half-maximal effective concentration: > 26000 nM
Compound 4: only a limit was reported (the forecaster's own chance of this, stated with the estimate: 75%); the middle value does not contradict the limit.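

Among the compounds shown here, compound 3 and compound 4 both stand at limits in this assay, and the step between them cannot be read, so no new step follows. The compounds shown leave open at what concentration, if any, a half-maximal effect appears in this assay.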